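The source may report more compounds than this note shows. Statements on the series, on what has been measured and on what is new or still open speak of the compounds shown alone.

Three compounds have been measured:

Compound 1, `CC1=C(C(=O)OCc2ccccc2)C(c2ccoc2)NC(=S)N1`, gives 20% in an assay on membranes from HeLa cells for displacement of a labelled ligand from adenosine receptor A3 (Homo sapiens), read by scintillation counting, with a stated time of 180 min, tested at 1 uM; on this read-out higher numbers stand for more inhibition at the one concentration tested (going by the name of the read-out) and lower numbers for less inhibition.
Compound 2, `CC1=C(C(=O)OCc2ccccc2)C(c2cccs2)NC(=S)N1`, gives 24% in this assay.
Compound 3, `CCSC(=O)C1=C(C)NC(=O)NC1c1ccoc1`, gives 1% in this assay.

Compounds 1 and 2 share a core and differ in one place: thiophen-2-yl in place of furan-3-yl on a saturated ring carbon. The measured step is a number 4 percentage points higher from compound 1 to compound 2 (within the scatter), so the two values cannot be told apart here. The core of compound 3 differs from that of compound 1 in more than one place; the difference between the two cores is not broken down here. Compound 3 stands lowest of the three, with compound 1 nearest and compound 2 furthest, both gaps lying beyond the scatter.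

Compound 4, `CCSC(=O)C1=C(C)NC(=O)NC1c1cccs1`, has not yet been measured. It differs from compound 3 as follows: thiophen-2-yl in place of furan-3-yl on a saturated ring carbon. This is the same kind of change as that from compound 1 to compound 2, though the surroundings differ: in compound 3 the neighbouring ring atom bears a (ethylsulfanyl)carbonyl group, whereas in compound 1 it bears a large group. Because the step of a number 4 percentage points higher from compound 1 to compound 2 (within the scatter) stayed within the scatter, the step for compound 4 is expected to be similarly small, a number 3 percentage points higher from compound 3 to compound 4 (within the scatter). Compound 4 is therefore estimated at 4%, between -6% and 14%.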

Compound 4, a percentage reported as inhibition, at one concentration (the size of the read-out at that concentration, not a potency): 1%
Beside the measured number, compound 4's estimate is 3 percentage points above it; low and high end bracket the measured number.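

Putting thiophen-2-yl in place of furan-3-yl on a saturated ring carbon gives no change at the digits printed from compound 3 to compound 4 (within the scatter) in this assay. Set beside the earlier step, the change looks the same on both cores: the same change on two cores in this assay, a number 4 percentage points higher (within the scatter) from compound 1 to compound 2 and no change at the digits printed (within the scatter) from compound 3 to compound 4, 4 percentage points apart, within the scatter of two such steps This shows only that the change produces no step beyond the scatter on either of these two cores; it does not show that the two groups are interchangeable on other cores, and with compound 3 at 1% and compound 4 at 1%, this pair reads so low that a further fall could hardly be seen.

The compounds shown leave open whether a pyridine ring or a simple phenyl ring on that saturated ring carbon would read differently on either core. For the compounds shown here, they also leave open what an amide or a carboxylic acid would do on the ring atom that bears the (ethylsulfanyl)carbonyl group, and no pair here differing in one place separates the differences between the two cores.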